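Amino for Hydrogen on a Shared Core

This account rests on a few compounds, and the source may have more. Where it says the series, first, only, none or still open, it means among the compounds named here.

Measured in a functional assay on T47D cells (Homo sapiens) for cytotoxicity, read by sulforhodamine B assay, with a stated time of 48 h; a lower number here means a stronger inhibitor of growth, a higher number a weaker inhibitor of growth:
compound 1, `ClCc1ccc(Cn2cnc3c(Cl)ncnc32)cc1`: "not determined" (no result reported)
compound 2, `ClCc1cccc(Cn2cnc3c(Cl)nc(Cl)nc32)c1`: 1950 nM

Within the data shown here, two compounds were tested, but only one carries a number. Compound 1 was run in this assay and returned "not determined" (no result reported), so on the numbers shown it stands nowhere: there is no value to place it against anything. Compound 2, which carries a second chloro group and has its chloromethyl group attached at a different point of the benzyl ring, gives 1950 nM in this assay. Among the measured compounds shown here, since no pair of measured compounds differs in one place, no step is available.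

Compound 3, `Nc1nc(Cl)c2ncn(Cc3ccc(CCl)cc3)c2n1`, is the unmeasured compound. It differs from compound 1 by amino in place of hydrogen on an aromatic carbon. The amino group is placed between two ring nitrogen atoms of the six-membered aromatic ring of the shared core.

With compound 1 without a number, the size of the step from compound 1 to compound 3 in this assay cannot be anchored; it is expected to be modest, in either direction, and may well lie within the scatter. Compound 3 is estimated at 3000 nM, with a range from 700 nM to 15000 nM.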

Compound 3, concentration for 50% growth inhibition: 6920 nM
The estimate for compound 3 lay 2.3-fold (0.36 log units) below the measured number; low and high end bracket the measured number.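

In this assay, among these compounds, compound 3 gives 6920 nM, while compound 1 carries no number, so no step between compound 1 and compound 3 can be read. Going by these compounds, whether amino in place of hydrogen on the shared core strengthens or weakens growth inhibition stays open. No evidence shown here bears on the value of compound 3.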